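This account rests on a few compounds, and the source may have more. Where it says the series, first, only, none or still open, it means among the compounds named here.

Compounds measured in a functional assay on HL-60 cells (Homo sapiens) for cytotoxicity, read by MTT assay, with a stated time of 24 h; on this read-out lower numbers stand for stronger inhibition and higher numbers for weaker inhibition:
compound 1, `OCCOc1c(Br)cc(Br)cc1Oc1ccc(Br)cc1Br`: 28.2 ug/mL
compound 2, `C#CCOc1c(Br)cc(Br)cc1Oc1ccc(Br)cc1Br`: 29.7 ug/mL
compound 3, `CC(=O)Oc1c(Br)cc(Br)cc1Oc1ccc(Br)cc1Br`: 29.9 ug/mL

All three share one core and differ only in the group carried on an oxygen on an aromatic ring. On the numbers shown, compound 1 has the lowest of the three values, but a 1.1-fold higher number from compound 1 to compound 2 (0.02 log units; within the scatter) and a 1.1-fold higher number from compound 1 to compound 3 (0.03 log units; within the scatter) both lie within the scatter, so the three compounds cannot be told apart; the remaining step, a 1.0-fold higher number from compound 2 to compound 3 (0.00 log units; within the scatter), is likewise within the scatter.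

Compound 4, `BrCCOc1c(Br)cc(Br)cc1Oc1ccc(Br)cc1Br`, is not yet measured. It differs from compound 1 by bromo in place of hydroxy on a saturated chain carbon, two bonds along the chain from an oxygen on an aromatic ring. Going by the values given here, the steps that bear on this change are the three above, since each of them also alters what is attached to an oxygen on an aromatic ring, and none of them moved the number beyond the scatter. Among the compounds with values here, on that evidence no step beyond the scatter is expected in this assay in either direction, though none of the measured steps exchanged hydroxy for bromo, so the guidance is indirect.

Compound 4 is therefore estimated at 29 ug/mL, with a range from 17 ug/mL to 50 ug/mL. The step this estimate expects is a 1.0-fold higher number from compound 1 to compound 4 (0.01 log units; within the scatter).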

Compound 4, half-maximal inhibitory concentration: 26.2 ug/mL
The estimate for compound 4 lay 1.1-fold (0.04 log units) above the measured number; the range from low to high includes it.
By their numbers in this assay, from the lowest: compounds 4, 1, 2 and 3 (each within the scatter of the next).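

In this assay, the exchange of hydroxy for bromo on a saturated chain carbon, two bonds along the chain from an oxygen on an aromatic ring, gives a 1.1-fold lower number from compound 1 to compound 4 (0.03 log units; within the scatter) and is the first step shown that keeps the chain intact and alters only its end group: the hydrogen-bond donor and acceptor counted for hydroxy are gone, yet the two compounds cannot be told apart. The other new comparisons agree, with 2-bromoethyl in place of acetyl giving a 1.1-fold lower number from compound 3 to compound 4 (0.06 log units; within the scatter) and bromomethyl in place of ethynyl giving a 1.1-fold lower number from compound 2 to compound 4 (0.05 log units; within the scatter), so all four compounds remain inseparable in this assay whichever of these groups the oxygen carries. Nothing shown explains why these groups cannot be separated on this read-out.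

Still open, going by these compounds, is whether an amine or a carboxylic acid at the end of this chain, or a longer chain in place of the 2-bromoethyl group, would give a step beyond the scatter. Every group shown falls within the scatter of the others. The compounds leave undecided whether anything carried on this oxygen can move the number at all.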